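Cyclohexyl substituent changes on the shared core

The source may report more compounds than this note shows. Statements on the series, on what has been measured and on what is new or still open speak of the compounds shown alone.

Measured so far in an assay on isolated protein for inhibition of protein kinase C delta type (Homo sapiens), read by TR-FRET, with a stated time of 2 h; on this read-out higher numbers stand for weaker inhibition and lower numbers for stronger inhibition:
compound 1 `N#Cc1cnc(NCc2cnccc2C(F)(F)F)cc1N[C@H]1CC[C@@H](O)CC1` gives 4500 nM
compound 2 `CO[C@H]1CC[C@H](Nc2cc(NCc3cnccc3C(F)(F)F)ncc2C#N)CC1` gives > 10000 nM, a limit of the assay and not a number
compound 3 `N#Cc1cnc(NCc2ccccc2C(F)(F)F)cc1N[C@H]1C[C@H](C(N)=O)C1` gives > 10000 nM, again only a limit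

Compound 2 stands at the limit; (the limit of > 10000 nM in this assay, at which 2 of the 3 values shown sit). Among the measured compounds shown here, the one measured step that touches it, an at least 2.2-fold higher number from compound 1 to compound 2 (0.34 log units; beyond the scatter), runs from the hydroxyl-bearing compound 1 to the methoxy-bearing compound 2 and is read against a limit, so its true size is unknown beyond its lower bound. For the measured compounds named here, compound 3 carries a carboxamide on a smaller ring and a different aromatic group and sits at the limit too, so no step to it is counted.

The next compound, compound 4 `CNC(=O)[C@H]1CC[C@@H](Nc2cc(NCc3cnccc3C(F)(F)F)ncc2C#N)CC1`, changes compound 2 as follows: 4-(methylcarbamoyl)cyclohexyl in place of 4-methoxycyclohexyl on a nitrogen on an aromatic ring. The entering group brings back a hydrogen-bond donor that compound 1 had and compound 2 lacked, while the measured step from compound 1 to compound 2 was at least modest. The estimate for compound 4 is therefore a step of an at least 1.6-fold lower number from compound 2 to compound 4 (0.22 log units; that floor lies within the scatter) back towards the range of compound 1, and compound 4 is expected to give about 6000 nM, between 2000 nM and 20000 nM, with a fair chance of only a limit being reported.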

Compound 4, half-maximal inhibitory concentration: 1600 nM
For compound 4 the middle estimate is 3.8-fold (0.57 log units) above the measured one, and the stated range ends above it.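

In this assay, the change to 4-(methylcarbamoyl)cyclohexyl gives an at least 6.2-fold lower number from compound 2 to compound 4 (0.79 log units; beyond the scatter), with the true size left open since compound 2 sits at a limit of the assay: the limit of > 10000 nM in this assay, at which 2 of the 4 values shown sit.

Methylcarbamoyl in place of hydroxy on a saturated ring carbon gives a 2.8-fold lower number from compound 1 to compound 4 (0.45 log units; beyond the scatter). The earlier step showed only a rise in the number on moving away from hydroxy at this place, whereas these steps show that a larger substituent here can give a lower number than the hydroxy group of compound 1.

Whether the amide hydrogen or the rest of the methylcarbamoyl group accounts for the difference stays open. Going by these compounds, how a dimethylcarbamoyl group, a carboxylic acid or an amine would read at this place also remains unknown.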